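The compounds below may be only part of what the source reports. "The series", "measured", "known", "first", "only" and "open" are said of these compounds alone.

Measured in an assay on the whole organism (plasma, strain Sprague-Dawley) for inhibition of Dipeptidyl peptidase 4 (Rattus norvegicus), with a stated time of 6 h, at a dose of 1 mg/kg by the oral route; on this read-out lower numbers stand for less inhibition and higher numbers for more inhibition at the one dose given (going by the name of the read-out):
Compound 1 `CCN(CC)C(=O)[C@@H]1CN[C@H](C(=O)N2CCC[C@H]2C#N)C1` gives 43%.
Compound 2 `CCNC(=O)[C@@H]1CN[C@H](C(=O)N2CCC[C@H]2C#N)C1` gives 60%.
Compound 3 `N#C[C@@H]1CCCN1C(=O)[C@@H]1C[C@H](C(=O)N2CCCCCC2)CN1` gives 68%.

Compound 3 holds the highest number of the three, though its margin over compound 2 is within the scatter; only the gap to compound 1 is beyond it, a number 25 percentage points higher from compound 1 to compound 3 (beyond the scatter). Compound 4 `N#C[C@@H]1CCCN1C(=O)[C@@H]1C[C@H](C(=O)N2CCC2)CN1` differs from compound 3 by azetidin-1-yl in place of azepan-1-yl on a carbonyl carbon. Going by the values given here, the steps that bear on this are those that swap the group on the same carbonyl carbon: a number 25 percentage points higher from compound 1 to compound 3 (beyond the scatter) and a number 8 percentage points higher from compound 2 to compound 3 (within the scatter). Among the compounds with values here, both moved toward the seven-membered ring, so no measured step tells how a four-membered ring behaves here. A modest fall is expected, a number 13 percentage points lower from compound 3 to compound 4 (beyond the scatter), and compound 4 is estimated at 55%, between 35% and 75%.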

Compound 4, a percentage reported as inhibition, in the whole organism at one dose (the size of the read-out at that dose, not a potency): 77%
Estimate against measurement, compound 4: 22 percentage points below; the whole stated range lies below it.
By their numbers in this assay, from the lowest: compound 1; then compounds 2, 3 and 4 (each within the scatter of the next, the first and the last beyond it).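

In this assay, azetidin-1-yl in place of azepan-1-yl on the carbonyl carbon gives a number 9 percentage points higher from compound 3 to compound 4 (within the scatter), so the two ring sizes cannot be told apart at this position. Compound 3 could not be separated from the ethylamino compound, but azetidin-1-yl can, with a number 17 percentage points higher from compound 2 to compound 4 (beyond the scatter), and the step from the diethylamino compound is larger, a number 34 percentage points higher from compound 1 to compound 4 (beyond the scatter). Nothing available explains these steps. Still open, as far as these compounds go, is how pyrrolidin-1-yl or piperidin-1-yl would read on this carbonyl carbon, and whether morpholin-4-yl, with its ring oxygen, would read the same.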